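A few compounds are considered here, and "the series" means these few. Any claim that something is new, unique, unknown or untested is made for them only; others in the source may bear on it.

Three compounds of the series have been run in a functional assay on the whole organism (integument) for inhibition, with Chilo suppressalis as the target, read by scintillation counting, with a stated time of 72 h; on this read-out higher numbers stand for weaker inhibition and lower numbers for stronger inhibition. Compound 1 `O=C(Nc1nnc(-c2ccc(Cl)cc2)s1)c1ccccc1` reaches only the limit of the assay, giving > 5010 nM. Compound 2 `O=C(Nc1nnc(-c2ccc(Cl)cc2)s1)c1c(F)cccc1F` likewise gives only a limit in this assay, > 5010 nM. Among the measured compounds shown here, compound 3 `COc1cccc(OC)c1C(=O)Nc1nnc(-c2ccc(Cl)cc2)s1` is the sole member with a measured number, giving 58.9 nM in this assay, and so stands alone among the values shown. The remaining two values sit at the limit of > 5010 nM in this assay, at which 2 of the 3 values shown sit. For the measured compounds named here, no pair of the measured compounds differs in a single place, so no measured step is available to calibrate the next change.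

Compound 4 `COc1cccc(OC)c1C(=O)Nc1nnc(-c2ccc(C(C)C)cc2)s1` has not yet been measured. It differs from compound 3 by isopropyl in place of chloro on an aromatic carbon, para to a large group. Going by the values given here, nothing among the measured compounds bears on this exchange; the two compounds without a number differ from compound 3 in another part of the molecule. The step from compound 3 to compound 4 is expected to be small, near the usual scatter and without a firm direction, a 1.7-fold higher number from compound 3 to compound 4 (0.23 log units; within the scatter). Compound 4 is accordingly expected to give about 100 nM in this assay, within a range from 25 nM to 600 nM.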

Compound 4, half-maximal inhibitory concentration: 398 nM
Estimate against measurement, compound 4: 4.0-fold (0.60 log units) below; the measured number falls inside the stated range.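

In this assay this position now has its first readable step, with isopropyl in place of chloro on an aromatic carbon giving a 6.8-fold higher number from compound 3 to compound 4 (0.83 log units; beyond the scatter). The position therefore responds to this exchange, and the 4-chlorophenyl group reads better than the 4-isopropylphenyl group, although compound 4 still gives a measured number rather than a limit. Nothing shown accounts for the size or direction of this step.

Still open, as far as these compounds go, is how other groups would read at this position, such as fluoro, bromo, methyl, methoxy or tert-butyl, and so whether the heavy-atom count tracks the read-out at all. Also open, from the compounds shown here alone, is whether the same exchange would give any measured number if carried onto compound 1 or compound 2, each of which stands only at a limit of the assay.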